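A few compounds are considered here, and "the series" means these few. Any claim that something is new, unique, unknown or untested is made for them only; others in the source may bear on it.

In a functional assay on NCI-H1975 cells (Homo sapiens) for cytotoxicity, read by MTT assay, with a stated time of 72 h (a lower number here means a stronger inhibitor, a higher number a weaker inhibitor), compound 1 `O=C(N/N=C/c1ccc(Br)cc1)N1CCc2ncnc(Nc3ccc(F)c(Cl)c3)c2C1` gives > 200000 nM, which is a limit of the assay and not a number. Within the data shown here, compound 2 `Cc1ccc(/C=N/NC(=O)N2CCc3ncnc(Nc4cccc(C(F)(F)F)c4)c3C2)cc1`, at 21300 nM, holds the only true number so far. Compound 3 `O=C(N/N=C/c1ccc(Br)cc1)N1CCc2ncnc(Nc3cccc(C(F)(F)F)c3)c2C1` changes its 4-methylphenyl to 4-bromophenyl, with bromo in place of methyl on an aromatic carbon. Among the measured compounds shown here, no measured pair isolates this change, so only a small shift toward weaker inhibition is expected, possibly none beyond the scatter. The expected step is a 1.4-fold higher number from compound 2 to compound 3 (0.15 log units; within the scatter). Compound 3 is estimated at 30000 nM, within an expected range of 10000 nM to 100000 nM.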

Compound 3, half-maximal inhibitory concentration: 61400 nM
Estimate against measurement, compound 3: 2.0-fold (0.31 log units) below; measured number inside the range.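

In this assay, among these compounds, the change from 4-methylphenyl to 4-bromophenyl gives the first step between two true numbers, a 2.9-fold higher number from compound 2 to compound 3 (0.46 log units; beyond the scatter), so this position para to a large group responds to the substituent, and bromo does not improve on methyl. With 4-bromophenyl held constant, 3-(trifluoromethyl)phenyl in place of 3-chloro-4-fluorophenyl gives an at least 3.2-fold lower number from compound 1 to compound 3 (0.51 log units; beyond the scatter). Compound 1 holds a limit of the assay, not a number: the limit of > 200000 nM in this assay, at which 1 of the 3 values shown sits.

Only methyl and bromo can be compared at this position. On these data alone, whether methoxy, a dimethylamino group or a carboxylic acid there would give a lower number than compound 2 remains open.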